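A few compounds are considered here, and "the series" means these few. Any claim that something is new, unique, unknown or untested is made for them only; others in the source may bear on it.

Among the measured compounds shown here, compound 2 `CC(=O)Nc1cccc(C2CCN(CCCn3c(-c4cccc(C(F)(F)F)c4)nc4ccccc43)CC2)c1` has the highest number of the two compounds measured so far in an assay for displacement of a labelled ligand from melanin-concentrating hormone receptor 1 (Homo sapiens), read by fluorescence (a higher number here means a weaker inhibitor, a lower number a stronger inhibitor), where compound 2 gives 30 nM. Its closest relative, compound 1 `CC(=O)Nc1cccc(C2CCN(CCCn3c(-c4cccc(Cl)c4)nc4ccccc43)CC2)c1`, gives 5 nM in this assay, and the step between them, a 6.0-fold higher number from compound 1 to compound 2 (0.78 log units; beyond the scatter), was trifluoromethyl in place of chloro on an aromatic carbon. Compound 3 `CC(=O)Nc1cccc(C2CCN(CCCn3c(-c4ccc(F)cc4)nc4ccccc43)CC2)c1` is the next compound to be tested, and it differs from compound 2 as follows: 4-fluorophenyl in place of 3-(trifluoromethyl)phenyl on an aromatic carbon. For the measured compounds named here, no measured step covers a 4-fluorophenyl group, so the single step from compound 1 to compound 2 is the only guide, and it shows only that a change at this position can shift the number modestly and beyond the scatter. Compound 3 is therefore estimated at 12 nM, within a range of 3 nM to 50 nM, which would be a step of a 2.5-fold lower number from compound 2 to compound 3 (0.40 log units; beyond the scatter).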

Compound 3, half-maximal inhibitory concentration: 56 nM
The estimate for compound 3 lay 4.7-fold (0.67 log units) below the measured number; measured number outside the range, above it.
By their numbers in this assay, from the lowest: compound 1; then compounds 2 and 3 (each within the scatter of the next).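

In this assay, the step of a 1.9-fold higher number from compound 2 to compound 3 (0.27 log units; within the scatter) is too small to tell 4-fluorophenyl and 3-(trifluoromethyl)phenyl apart at this position, even though the two groups differ in both substituent and ring location. The step of an 11-fold higher number from compound 1 to compound 3 (1.05 log units; beyond the scatter) is large, and together with a 6.0-fold higher number from compound 1 to compound 2 (0.78 log units; beyond the scatter) it sets 3-chlorophenyl apart from both other groups, which makes compound 1 the strongest inhibitor of the three. No measurement shown explains why this one group stands apart.

Going from compound 1 to compound 3 changes both the substituent and its place on the phenyl ring, so these compounds cannot show which of the two matters. A 4-chlorophenyl or 3-fluorophenyl group would separate those two changes, while an unsubstituted phenyl group would show what the chloro substituent adds.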